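A Methyl on the Ring Amine: Expectation for Compound 3

The compounds below may be only part of what the source reports. "The series", "measured", "known", "first", "only" and "open" are said of these compounds alone.

Compound 1 `CCn1cc(-c2nc3ccccc3[nH]2)c(=O)c2cc(F)c(N3CCNCC3)cc21` and compound 2 `CCn1cc(-c2nc3ccc(N)cc3[nH]2)c(=O)c2cc(F)c(N3CCNCC3)cc21` share one core and differ in one place only. In a functional assay on Hep 3B2 cells (Homo sapiens) for cytotoxicity, read by sulforhodamine B assay, with a stated time of 48 h (a higher number here means a weaker inhibitor of growth, a lower number a stronger inhibitor of growth), compound 1 gives a value that is an assay limit, > 10000 nM. Compound 2 likewise reaches only the limit in this assay, > 10000 nM. The step that the two limits leave unreadable from compound 1 to compound 2 cannot be read, since both values sit at the limit of > 10000 nM in this assay, at which 2 of the 2 values shown sit. Compound 3 `CCn1cc(-c2nc3ccc(N)cc3[nH]2)c(=O)c2cc(F)c(N3CCN(C)CC3)cc21` carries the change methyl in place of hydrogen on an amine nitrogen in a ring relative to compound 2; the same difference, cut one bond further out, reads piperazin-1-yl to 4-methylpiperazin-1-yl. Among the measured compounds shown here, no measured step touches this ring amine, so the numbers give no ground to expect a gain or loss in this assay beyond the scatter. Compound 3 is therefore expected to remain near the limit, with an estimated 15000 nM (range 5000 nM to 50000 nM). The expected step that the limit leaves unreadable from compound 2 to compound 3 is essentially nil.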

Compound 3, concentration for 50% growth inhibition: > 10000 nM
Compound 3: a limit, no number; the forecaster's own chance of this, stated with the estimate: 85%; the middle value lies beyond the limit too.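

No new step can be read from compound 2 to compound 3, since each reaches only an assay limit: (the limit of > 10000 nM in this assay, at which 3 of the 3 values shown sit). The compounds shown leave open whether amino or methyl on the shared core changes growth inhibition at all in this assay, as none gives a readable number.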